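The source may report more compounds than this note shows. Statements on the series, on what has been measured and on what is new or still open speak of the compounds shown alone.

In an ADME assay on MDCK cells (Canis lupus familiaris) for cytotoxicity, read by MTT assay, with a stated time of 72 h (on this read-out lower numbers stand for stronger inhibition and higher numbers for weaker inhibition), compound 1 `Cc1cc(/C=C/c2ccc(O)cc2)[nH]n1` gives 80000 nM, and compound 2 `COc1ccc(/C=C/c2cc(C)n[nH]2)cc1` gives 16500 nM. The change hydrogen in place of methyl on an oxygen on an aromatic ring made the step of a 4.8-fold higher number from compound 2 to compound 1 (0.69 log units; beyond the scatter). Compound 3 `COc1ccc(/C=C/C(=O)CC(C)=O)cc1` is built on another core; the difference between the two cores is not broken down here. In this assay compound 3 gives 41600 nM. Compound 4 `CC(=O)CC(=O)/C=C/c1ccc(O)cc1` has not yet been measured. It differs from compound 3 by hydrogen in place of methyl on an oxygen on an aromatic ring, the same change as that from compound 2 to compound 1, now on the other core. Because that change gave a 4.8-fold higher number from compound 2 to compound 1 (0.69 log units; beyond the scatter), a step in the same direction is expected for compound 4, estimated as a 3.6-fold higher number from compound 3 to compound 4 (0.56 log units; beyond the scatter); the two cores are not the same, which leaves room for a smaller step. Compound 4 is therefore estimated at 150000 nM, with a likely range from 60000 nM to 400000 nM.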

Compound 4, half-maximal inhibitory concentration: 30600 nM
For compound 4 the middle estimate is 4.9-fold (0.69 log units) above the measured one; measured number below the stated range.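

In this assay, putting hydroxy in place of methoxy gave a 1.4-fold lower number from compound 3 to compound 4 (0.13 log units; within the scatter), so on this core the change stands out from the usual scatter no more than repeat measurements would. Set beside the earlier step, the same change did not carry over from one core to the other: the same change on two cores in this assay, a 4.8-fold higher number (0.69 log units; beyond the scatter) from compound 2 to compound 1 and a 1.4-fold lower number (0.13 log units; within the scatter) from compound 3 to compound 4, 6.6-fold (0.82 log units) apart, beyond the scatter of two such steps. For these two pairs, the size of the step therefore depends on the core, but two pairs cannot show which part of the cores matters or predict the step on a further core.

The compounds shown leave open how a longer chain on that oxygen on the aromatic ring would behave on either core. They also leave open what an amine in place of the hydroxy would do.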